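A few compounds are considered here, and "the series" means these few. Any claim that something is new, unique, unknown or untested is made for them only; others in the source may bear on it.

Measured in a functional assay on KB cells (Homo sapiens) for inhibition, read by sulforhodamine B assay, with a stated time of 72 h; a lower number here means a stronger inhibitor of growth, a higher number a weaker inhibitor of growth:
compound 1 `CCOC(=O)/C=C/c1ccncc1-c1ccc2ccccc2c1`: > 10000 nM, a limit
compound 2 `O=C(O)/C=C/c1ccncc1-c1ccc2ccccc2c1`: > 10000 nM, a limit

Compound 2 has only a limit, > 10000 nM. Among the compounds with values here, the series so far stands at the limit of > 10000 nM in this assay, at which 2 of the 2 values shown sit.

Compound 3 `CNC(=O)CCc1ccncc1-c1ccc2ccccc2c1` carries 2-(methylcarbamoyl)ethyl in place of 2-carboxyethenyl on an aromatic carbon, opposite the ring nitrogen.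

Within the data shown here, the one measured step, a step that the two limits leave unreadable from compound 1 to compound 2, gives no size to carry over. No step beyond the scatter is therefore expected in this assay, and no direction can be argued. The expected step is a step that the limit leaves unreadable from compound 2 to compound 3. The estimate for compound 3 is 12000 nM, with an expected range of 4000 nM to 40000 nM.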

Compound 3, concentration for 50% growth inhibition: > 10000 nM
Compound 3 ended at the assay's limit; the forecaster's own chance of this, stated with the estimate: 75%; the middle value lies beyond the limit too.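

In this assay no step can be read from compound 1 or compound 2 to compound 3, as all three values are limits: the limit of > 10000 nM in this assay, at which 3 of the 3 values shown sit.
The compounds shown leave open how compound 1, compound 2 and compound 3 actually rank, and which change at this position, if any, alters growth inhibition.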